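This account rests on a few compounds, and the source may have more. Where it says the series, first, only, none or still open, it means among the compounds named here.

Measured compounds and their values:

Compound 1 `COc1ccc2c(c1)c(/C=C1/C(=O)Nc3ccc(F)cc31)cn2Cc1cn([C@@H]2O[C@H](COC(C)=O)[C@@H](OC(C)=O)[C@H](OC(C)=O)[C@H]2OC(C)=O)nn1` in an ADME assay on NIH3T3 cells (Homo sapiens) for cytotoxicity, read by sulforhodamine B assay, with a stated time of 48 h (on this read-out higher numbers stand for weaker inhibition and lower numbers for stronger inhibition), gives > 200000 nM and this is a limit of the assay rather than a number.
Compound 2 `CC(=O)OC[C@H]1O[C@@H](n2cc(CN3C(=O)/C(=C\c4ccccc4)c4ccccc43)nn2)[C@H](OC(C)=O)[C@@H](OC(C)=O)[C@@H]1OC(C)=O` gives 22800 nM in this assay.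
Compound 3 `CC(=O)OC[C@H]1O[C@@H](n2cc(CN3C(=O)/C(=C/c4ccccc4)c4ccccc43)nn2)[C@H](OC(C)=O)[C@@H](OC(C)=O)[C@@H]1OC(C)=O` gives > 100000 nM in this assay and this too is a limit of the assay.

Compound 3 therefore stands at a limit, not at a measured number; of the three values shown, only compound 2 gives a true number, while compound 1 sits at the limit of > 200000 nM in this assay, at which 1 of the 3 values shown sits, and compound 3 at the limit of > 100000 nM in this assay, at which 1 of the 3 values shown sits. Among the compounds with values here, the one measured step between compounds that differ in a single place is an at least 4.3-fold higher number from compound 2 to compound 3 (0.64 log units; beyond the scatter), and this step rests on the fact that compounds 2 and 3 differ only in the configuration as drawn alone.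

Compound 4 `CC(=O)OC[C@H]1O[C@@H](n2cc(CN3C(=O)/C(=C/C=C/c4ccccc4)c4ccccc43)nn2)[C@H](OC(C)=O)[C@@H](OC(C)=O)[C@@H]1OC(C)=O` brings a different kind of change: 2-phenylethenyl in place of phenyl on a double-bonded chain carbon bound to a double-bonded ring carbon. Within the data shown here, no measured step involves such a replacement of a group, so the single measured step gives no direct guide to its size or direction. With compound 3 already at a limit of weak inhibition, the expected outcome for compound 4 is a value in the same region, with no step beyond the scatter. The step from compound 3 to compound 4 is estimated as a number no higher from compound 3 to compound 4 (the limit leaves the size open). Compound 4 is expected to give about 100000 nM, within a range of 25000 nM to 300000 nM.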

Compound 4, half-maximal inhibitory concentration: 12300 nM
Compound 4: middle estimate off by 8.1-fold (0.91 log units), on the high side; measured number below the stated range.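

On a double-bonded chain carbon bound to a double-bonded ring carbon, putting 2-phenylethenyl in place of phenyl is the first change of a group among these compounds, and in this assay it gives an at least 8.1-fold lower number from compound 3 to compound 4 (0.91 log units; beyond the scatter). This shows that the position responds to which group it carries, not only to how the double bond is drawn, and that this change moves the read-out towards stronger inhibition of the cells. The true size of the step stays unknown because compound 3 stands at a limit of the assay rather than at a number: the limit of > 100000 nM in this assay, at which 1 of the 4 values shown sits.

From the compounds shown here alone, one pair of compounds cannot tell whether the lower number comes from the extra double bond outside the aromatic ring, from the greater length of the group, or from something else, so the reason for the step remains open. Going by these compounds, it is also open whether the saturated 2-phenylethyl group, or a phenyl ring carrying an amine or a carboxylic acid, would behave like 2-phenylethenyl at this position in this assay.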